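Replacing the dichlorophenyl group: notes toward compound 3

The source may hold more compounds than are shown below. What is called first, only, known or untested is meant among the compounds shown, and "the series" means these compounds.

Going by the values given here, compound 1 `COc1cc(C(=O)c2sc(-c3ccc(Cl)c(Cl)c3)cc2N)cc(OC)c1OC` gives 270 nM in a functional assay on MOLT-4 cells (Homo sapiens) for antiproliferative activity (on this read-out lower numbers stand for stronger inhibition and higher numbers for weaker inhibition), the lowest of the two numbers so far; compound 2 `COc1cc(C(=O)c2sc(-c3cc(OC)c(OC)c(OC)c3)cc2N)cc(OC)c1OC` gives 1200 nM in this assay, a gap beyond the scatter. Compound 3 `COc1cc(C(=O)c2sc(-c3ccc([N+](=O)[O-])cc3)cc2N)cc(OC)c1OC` carries 4-nitrophenyl in place of 3,4-dichlorophenyl on an aromatic carbon. Among the compounds with values here, no step between measured compounds covers this exchange, so the expectation rests on compound 1 alone and on compound 2 standing at a higher number. For compound 3 a modest step toward a higher number is expected, a 1.9-fold higher number from compound 1 to compound 3 (0.27 log units; within the scatter), at the edge of the scatter. Compound 3 is estimated at 500 nM, with a range from 150 nM to 1800 nM.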

Compound 3, half-maximal inhibitory concentration: 110 nM
Beside the measured number, compound 3's estimate is 4.5-fold (0.66 log units) above it; measured number below the stated range.
By their numbers in this assay, from the lowest: compound 3; then compound 1; then compound 2.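

At the aromatic carbon next to the ring sulfur, 4-nitrophenyl in place of 3,4-dichlorophenyl brings a 2.5-fold lower number from compound 1 to compound 3 (0.39 log units; beyond the scatter) in this assay and so shows that this position tolerates an aryl group without chlorine while the number still falls. Nothing measured on these compounds accounts for the step.

From the compounds shown here alone, how a phenyl group carrying an amine or a carboxylic acid in place of the nitro group would stand remains open. The same holds for an unsubstituted phenyl group at this position.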